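A few compounds are considered here, and "the series" means these few. Any claim that something is new, unique, unknown or untested is made for them only; others in the source may bear on it.

Compound 1 `O=S(=O)(c1ccc(-c2cnc(C3CC3)o2)cc1)N1CCSc2ccccc21` gives 48 nM in a functional assay on HepG2 cells (Homo sapiens) for antiproliferative activity, read by MTT assay, with a stated time of 72 h; a lower number here means a stronger inhibitor, a higher number a weaker inhibitor.
Compound 2 `Nc1ccc2c(c1)OCCCN2S(=O)(=O)c1ccc(-c2cnc(C3CC3)o2)cc1` gives 100 nM in this assay.
Compound 3 `O=S(=O)(c1ccc(-c2cnc(C3CC3)o2)cc1)N1CCCOc2ccc(F)cc21` gives 36 nM in this assay.

Of the three measured compounds, compound 2 stands at the highest number in this assay; compound 1 sits below it by a step beyond the scatter, and compound 3 sits further below still. Compound 4 `Cc1ccc2c(c1)OCCCN2S(=O)(=O)c1ccc(-c2cnc(C3CC3)o2)cc1` differs from compound 2 by methyl in place of amino on an aromatic carbon. For the measured compounds named here, no pair of measured compounds shows this same change, so its effect is not known directly. Compound 1, which carries no substituent on that ring, gives 48 nM, and compound 4 is expected to fall in that neighbourhood. Compound 4 is estimated at 55 nM, with a range from 25 nM to 130 nM. This corresponds to an expected step of a 1.8-fold lower number from compound 2 to compound 4 (0.26 log units; within the scatter), toward lower numbers and of modest size.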

Compound 4, half-maximal inhibitory concentration: 795 nM
Beside the measured number, compound 4's estimate is 14-fold (1.16 log units) below it; the measured number lies above the stated range.
By their numbers in this assay, from the lowest: compounds 3 and 1 (each within the scatter of the next); then compound 2; then compound 4.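

In this assay, for the compounds shown here, methyl in place of amino on this aromatic carbon gives an 8.0-fold higher number from compound 2 to compound 4 (0.90 log units; beyond the scatter) and so provides the first direct reading of this position, which proves sensitive to the group it carries. The change removes the hydrogen-bond donor and acceptor counted for amino, and the number rises with it, though this single pair cannot link the two. Nothing available here accounts for the step.

From the compounds shown here alone, whether the step reflects losing amino or gaining methyl remains open. A hydroxyl or methoxy group on the same carbon of this core would help separate the two readings.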